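A few compounds are considered here, and "the series" means these few. Any claim that something is new, unique, unknown or untested is made for them only; others in the source may bear on it.

In an ADME assay on L6 cells (Rattus norvegicus) for cytotoxicity (on this read-out higher numbers stand for weaker inhibition and lower numbers for stronger inhibition), compound 1 (`O=C(CN1CCCCC1)OC1CC2(N3CCCCC3)CC(c3ccccc3)C1C(c1ccccc1)C2`) stands at 60400 nM; > 184000 nM (2 entries) without a single number. One of the entries of compound 1 is a limit of the assay and not a number. Within the data shown here, compound 2 (`O=C(CCN1CCCC1)OC1CC2(N3CCCC3)CC(c3ccccc3)C1C(c1ccccc1)C2`) gives 21900 nM as the only single number so far, and it is the reference point for what follows.

Compound 3 (`O=C(CCN1CCCC1)OC1CC2(N3CCCCC3)CC(c3ccccc3)C1C(c1ccccc1)C2`) differs from compound 2 in one place only, and piperidin-1-yl in place of pyrrolidin-1-yl on a saturated ring carbon is the whole change: piperidin-1-yl in place of pyrrolidin-1-yl on a saturated ring carbon, with the rest of the structure untouched.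

Among the measured compounds shown here, no two measured compounds differ in one place alone, so no measured step speaks directly to this change in this assay and the expectation has to rest on compound 2 at 21900 nM as its anchor. No step beyond the scatter is expected. The expected size is a 1.3-fold higher number from compound 2 to compound 3 (0.11 log units; within the scatter) and no more than the usual scatter of repeated measurements. The estimate for compound 3 is 28000 nM with an expected range from 11000 nM to 70000 nM for now.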

Compound 3, half-maximal inhibitory concentration: 12500 nM
Compound 3: middle estimate off by 2.2-fold (0.35 log units), on the high side; the range from low to high includes it.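

In this assay, among these compounds, the first step that can be read at this ring carbon, two ring bonds from the ring atom that bears the ((2-(pyrrolidin-1-yl)ethyl)carbonyl)oxy group, is piperidin-1-yl in place of pyrrolidin-1-yl, with a 1.8-fold lower number from compound 2 to compound 3 (0.24 log units; within the scatter). The two rings therefore cannot be told apart on this read-out, and in this pair the six-membered amine at this position leaves the cytotoxicity reading where the five-membered amine had it, within repeat variation. Caution is also needed with single readings in this assay, since compound 1 has entries that do not settle on one value, one of them being a limit of the assay and not a number: the several entries of compound 1 in this assay, 60400 nM; > 184000 nM (2 entries).

Going by these compounds, whether this ring carbon stays as indifferent with a morpholin-4-yl group, an open-chain dimethylamino group or a primary amine remains open, since both groups compared so far are saturated rings with a single nitrogen. On these data alone, the step also rests on one pair with the 2-(pyrrolidin-1-yl)ethyl side chain of the ester held fixed, so whether the same swap reads the same beside a longer chain on that ester is unknown.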